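The compounds below may be only part of what the source reports. "The series", "measured", "known", "first", "only" and "open" are said of these compounds alone.

Three compounds share one core. Compound 1 `C[C@]1(CN2CCc3nc(N4CCCCC4)ccc3C2)Cn2cc([N+](=O)[O-])nc2O1` and compound 2 `C[C@]1(CN2CCc3nc(N4CCC(F)(F)CC4)ccc3C2)Cn2cc([N+](=O)[O-])nc2O1` have no result in an ADME assay on Vero cells (Chlorocebus sabaeus) for cytotoxicity, read by MTT assay, with a stated time of 72 h; on this read-out lower numbers stand for higher toxicity in this test and higher numbers for lower toxicity in this test: for compound 1 this assay records "not determined" (no result reported), and for compound 2 it records "not determined" (no result reported). Compound 3 `C[C@]1(CN2CCc3nc(-c4cccc(F)c4F)ccc3C2)Cn2cc([N+](=O)[O-])nc2O1` is the only one with an entry. In this assay compound 3 gives > 32 ug/mL, which is a limit of the assay and not a number. Compound 3 therefore sits at the limit of > 32 ug/mL in this assay, at which 1 of the 3 values shown sits. Compound 4 `C[C@]1(CN2CCc3nc(-c4ccc(F)c(Cl)c4)ccc3C2)Cn2cc([N+](=O)[O-])nc2O1` carries 3-chloro-4-fluorophenyl in place of 2,3-difluorophenyl on an aromatic carbon. Among the measured compounds shown here, no step between measured compounds is known, so no size of step is set by the data; the author expects none beyond the scatter, with the limit likely reported again. He estimates that compound 4 gives 40 ug/mL, between 20 ug/mL and 100 ug/mL, an expected step that the limit leaves unreadable from compound 3 to compound 4.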

Compound 4, half-maximal cytotoxic concentration: > 32 ug/mL
Compound 4: a limit, no number; the forecaster's own chance of this, stated with the estimate: 75%; the middle value lies beyond the limit too.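

In this assay, compound 3 and compound 4 both end at a limit and not a number, so no step between them can be read: the limit of > 32 ug/mL in this assay, at which 2 of the 4 values shown sit.

The compounds shown leave open whether 3-chloro-4-fluorophenyl and 2,3-difluorophenyl differ at all in this assay.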